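Benzyloxycarbonyl in place of methyl: notes on the series

The source may hold more compounds than are shown below. What is called first, only, known or untested is meant among the compounds shown, and "the series" means these compounds.

Measured in a functional assay on A549 cells (Homo sapiens) for antiproliferative activity, read by MTT assay, with a stated time of 48 h; a lower number here means a stronger inhibitor, a higher number a weaker inhibitor:
- compound 1 `COc1ccc(-c2nn(-c3ccccc3)cc2-c2nc3cc(Br)ccc3[nH]2)cc1` gives 6370 nM
- compound 2 `COc1ccc(-c2nn(-c3ccccc3)cc2-c2nc3cc(C(F)(F)F)ccc3[nH]2)cc1` gives 4820 nM
- compound 3 `COc1ccc(-c2nn(-c3ccccc3)cc2-c2nc3cc(C)ccc3[nH]2)cc1` gives 5070 nM

Compound 3 (5070 nM) is not separated from the other two compounds. The measured steps are (a 1.3-fold lower number from compound 1 to compound 2 (0.12 log units; within the scatter)), (a 1.3-fold lower number from compound 1 to compound 3 (0.10 log units; within the scatter)) and (a 1.1-fold higher number from compound 2 to compound 3 (0.02 log units; within the scatter)), and all of them lie within the scatter.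

The next change leads to compound 4 `COc1ccc(-c2nn(-c3ccccc3)cc2-c2nc3cc(C(=O)OCc4ccccc4)ccc3[nH]2)cc1` and is benzyloxycarbonyl in place of methyl on an aromatic carbon. Within the data shown here, the three measured steps are the only evidence that bears on it. They exchange bromo, trifluoromethyl and methyl among themselves, and none of them brings in a carbonyl or an added ring. They therefore guide this change only loosely, and the data do not show how a group of this kind behaves in this assay.

Among the measured compounds shown here, with compound 3 at 5070 nM as the anchor and a flat set of steps so far, no shift beyond the scatter is expected, though with wide uncertainty in either direction. The estimated step is (a 1.1-fold higher number from compound 3 to compound 4 (0.04 log units; within the scatter)). For compound 4 the estimated value is 5500 nM (expected range 2000 nM to 15000 nM).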

Compound 4, half-maximal inhibitory concentration: 11900 nM
Beside the measured number, compound 4's estimate is 2.2-fold (0.34 log units) below it; measured number inside the range.
By their numbers in this assay, from the lowest: compounds 2, 3, 1 and 4 (each within the scatter of the next, the first and the last beyond it).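

In this assay, the position para to a fused ring and meta to a fused ring now shows that a change there can pass the scatter, as the series had not shown before: both (a 2.3-fold higher number from compound 3 to compound 4 (0.37 log units; beyond the scatter)) and (a 2.5-fold higher number from compound 2 to compound 4 (0.39 log units; beyond the scatter)) are modest steps towards a weaker number with benzyloxycarbonyl on the aromatic carbon. The separation is incomplete, however, and compound 1 goes against any clean split between benzyloxycarbonyl and the other three groups, as (a 1.9-fold higher number from compound 1 to compound 4 (0.27 log units; within the scatter)) remains within the scatter. No measurement at hand bears on the reason for this result.

The change brings in a carbonyl, an ester oxygen and a six-membered aromatic ring together, and these compounds leave open which of these parts, if any single one, carries the modest steps. A carboxylic acid, a methyl ester or a benzyl amide on the same aromatic carbon would separate these parts and show whether the shift seen with compound 4 depends on the added ring or on the carbonyl.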